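Thiophen-2-yl in place of 3-methylphenyl on a shared core

A few compounds are considered here, and "the series" means these few. Any claim that something is new, unique, unknown or untested is made for them only; others in the source may bear on it.

Measured compounds:
compound 1 `COc1ccc(-c2cn3ccnc3c(-c3ccc4ncn(C5CCCCC5)c4c3)n2)cc1` gives 1.41
compound 2 `c1ccc2c(-c3cn4ccnc4c(-c4ccc5ncn(C6CCCCC6)c5c4)n3)cccc2c1` gives 1.44
compound 3 `Cc1cccc(-c2cn3ccnc3c(-c3ccc4ncn(C5CCCCC5)c4c3)n2)c1` gives 1.87

In a physicochemical assay for lipophilicity, using the shake flask method, in phosphate buffer, measured as octanol-water partition, with a stated time of 85 min, at pH 7.4 (on this read-out lower numbers stand for lower lipophilicity and higher numbers for higher lipophilicity), compound 3 stands highest of the three values. The step of a number 0.46 log units higher from compound 1 to compound 3 (beyond the scatter) and the step of a number 0.43 log units higher from compound 2 to compound 3 (beyond the scatter) both lie beyond the scatter, while the step of a number 0.03 log units higher from compound 1 to compound 2 (within the scatter) lies within it, so compound 1 and compound 2 are not told apart by these numbers.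

Compound 4 `c1csc(-c2cn3ccnc3c(-c3ccc4ncn(C5CCCCC5)c4c3)n2)c1` is not yet measured. Relative to compound 3 the change is thiophen-2-yl in place of 3-methylphenyl on an aromatic carbon.

Within the data shown here, no measured step involves thiophen-2-yl, so the expectation rests on how the three aryl exchanges at this position behaved: the step of a number 0.46 log units higher from compound 1 to compound 3 (beyond the scatter) and the step of a number 0.43 log units higher from compound 2 to compound 3 (beyond the scatter) were modest, and the step of a number 0.03 log units higher from compound 1 to compound 2 (within the scatter) was within the scatter. Exchanging the group at this position has therefore moved this assay by at most a modest amount, and a modest step downward from compound 3 is expected, a number 0.42 log units lower from compound 3 to compound 4 (beyond the scatter). Compound 4 is accordingly estimated at 1.45, with a range from 1.05 to 1.85.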

Compound 4, partition coefficient: 1.38
For compound 4 the middle estimate is 0.07 log units above the measured one; the measured number falls inside the stated range.
By their numbers in this assay, from the lowest: compounds 4, 1 and 2 (each within the scatter of the next); then compound 3.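

In this assay, the exchange of 3-methylphenyl for thiophen-2-yl gives a number 0.49 log units lower from compound 3 to compound 4 (beyond the scatter), whereas the exchanges from the other two aryl groups give a number 0.06 log units lower from compound 2 to compound 4 (within the scatter) and a number 0.03 log units lower from compound 1 to compound 4 (within the scatter). This shows that a five-membered aromatic ring with a sulfur atom can stand at this position without being told apart from 4-methoxyphenyl or naphthalen-1-yl, so that a change in ring size and the entry of a hetero atom into the ring do not by themselves separate these compounds. Among the four compounds, only compound 3, with its 3-methylphenyl group, stands apart, and nothing measured here accounts for that.

Every group shown at this position is an aromatic ring, so the effect on the read-out of an amine, a carboxylic acid or a longer alkyl chain remains open, as does that of a pyridine ring. The cyclohexyl group on the shared core is also the same throughout, which leaves open whether exchanging it would move the values in this assay by more or less than the aryl exchanges did.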